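A few compounds are considered here, and "the series" means these few. Any claim that something is new, unique, unknown or untested is made for them only; others in the source may bear on it.

The account is set in an in vitro assay on HEK385-7 cells for displacement of a labelled ligand from prostaglandin D2 receptor 2 (Homo sapiens); on this read-out lower numbers stand for stronger inhibition and higher numbers for weaker inhibition. Compound 1, `N#Cc1cc(-c2nc(C(c3ccc(F)cc3)c3ccc(F)cc3)sc2CC(=O)O)ccc1F`, is the anchor: in this assay compound 1 gives 57 nM, the lower of the two numbers in hand. The nearest number belongs to compound 2, `O=C(O)Cc1sc(C(c2ccccc2)c2ccccc2)nc1-c1ccccc1`, which in this assay gives 570 nM, a gap that lies beyond the scatter of repeat measurements. Compound 3, `Nc1nc(-c2ccc(Cl)cc2)c(CC(=O)O)s1`, gives in this assay only > 100000 nM. That value is a limit of the assay and not a number; it is the one described by the limit of > 100000 nM in this assay, at which 1 of the 3 values shown sits.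

The step now taken leads from compound 1 to compound 4, `O=C(O)Cc1sc(C(c2ccc(F)cc2)c2ccc(F)cc2)nc1-c1ccnc(F)c1`. The change is 2-fluoropyridin-4-yl in place of 3-cyano-4-fluorophenyl on an aromatic carbon. Within the data shown here, no pair among the measured compounds differs in just this way, so the size of the step has no direct precedent. Among the measured compounds shown here, since compound 4 keeps the fluorine-bearing side rings and the carboxymethyl group of compound 1, and the only exchange is the ring on the core, the expectation is a small step that stays within the scatter, with a slight lean toward a higher number, as the step of a 1.9-fold higher number from compound 1 to compound 4 (0.29 log units; within the scatter) expresses. Compound 4 is therefore estimated to give about 110 nM in this assay, with a likely range from 40 nM to 350 nM.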

Compound 4, half-maximal inhibitory concentration: 0.48 nM
Compound 4: middle estimate off by 230-fold (2.36 log units), on the high side, and the stated range ends above it.
By their numbers in this assay, from the lowest: compound 4; then compound 1; then compound 2. At a limit, above all of these: compound 3.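

Among these compounds, the exchange of 3-cyano-4-fluorophenyl for 2-fluoropyridin-4-yl on the aromatic carbon next to the ring nitrogen gives, in this assay, a 120-fold lower number from compound 1 to compound 4 (2.07 log units; beyond the scatter), so this position can move the read-out by a wide margin, which the earlier compounds could not show because no two of them differ in one place only. The entering group has fewer heavy atoms and no triple bond, has a ring nitrogen that the leaving group's ring lacks, and matches the leaving group in its count of hydrogen-bond acceptors, so the lower number comes with a smaller group on this carbon, at least in this one pair. Nothing measured here bears on why this exchange has so large an effect.

This single step changes the ring atoms, the nitrile and the place of the fluorine together, and the compounds shown do not separate these changes from one another. From the compounds shown here alone, it remains open whether a pyridin-4-yl ring without fluorine, a 2-fluorophenyl ring or a 2-methoxypyridin-4-yl ring on the same carbon would keep a number as low as that of compound 4.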